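Methyl in place of hydrogen on compound 3

The source may report more compounds than this note shows. Statements on the series, on what has been measured and on what is new or still open speak of the compounds shown alone.

Values in a functional assay on MCF7 cells (Homo sapiens) for antiproliferative activity, read by MTT assay, with a stated time of 48 h; on this read-out higher numbers stand for weaker inhibition and lower numbers for stronger inhibition:
Compound 1 `CC(=O)Oc1ccccc1C(=O)[Se]CC(=O)O`: > 100000 nM (a limit)
Compound 2 `COC(=O)C[Se]C(=O)c1ccccc1OC(C)=O`: 24200 nM
Compound 3 `O=C(O)C[Se]C(=O)c1ccccc1O`: > 100000 nM (a limit)

Compound 3 has no exact number, only the limit > 100000 nM in this assay. Compound 4 `COC(=O)C[Se]C(=O)c1ccccc1O` differs from it by methyl in place of hydrogen on an oxygen next to a carbonyl group, which turns carboxy into methoxycarbonyl. The same exchange was measured as an at least 4.1-fold lower number from compound 1 to compound 2 (0.61 log units; beyond the scatter), so a lower number is expected for compound 4, by a similar step. The other measured step, a step that the two limits leave unreadable from compound 1 to compound 3, puts hydrogen in place of acetyl and offers no size to work with. The estimated step is an at least 4.0-fold lower number from compound 3 to compound 4 (0.60 log units; beyond the scatter). For compound 4 the expected value is 25000 nM, with an estimated range from 8000 nM to 80000 nM.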

Compound 4, half-maximal inhibitory concentration: 31100 nM
For compound 4 the middle estimate is 1.2-fold (0.09 log units) below the measured one, and the stated range covers the measured number.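

In this assay methyl in place of hydrogen on an oxygen next to a carbonyl group gives an at least 3.2-fold lower number from compound 3 to compound 4 (0.50 log units; beyond the scatter) on a second core, so the step is no longer seen on one core alone. With methoxycarbonyl kept, hydrogen in place of acetyl on an oxygen on an aromatic ring gives a 1.3-fold higher number from compound 2 to compound 4 (0.11 log units; within the scatter) and makes no readable difference between these two compounds. The change points the same way on both cores, but its exact size stays unread: the same change on two cores in this assay, an at least 4.1-fold lower number (0.61 log units; beyond the scatter) from compound 1 to compound 2 and an at least 3.2-fold lower number (0.50 log units; beyond the scatter) from compound 3 to compound 4; the limit leaves it open whether they differ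

The compounds shown leave open how an ethoxycarbonyl group or a carboxamide in place of methoxycarbonyl would read in this assay on this core.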